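Swapping the aryl group: cytotoxicity of compound 3 expected

This account rests on a few compounds, and the source may have more. Where it says the series, first, only, none or still open, it means among the compounds named here.

Of the compounds shown here, two sharing one core have been tested in an ADME assay on Vero cells (Chlorocebus sabaeus) for cytotoxicity, read by MTT assay, with a stated time of 72 h; on this read-out higher numbers stand for lower toxicity in this test and lower numbers for higher toxicity in this test. Compound 1 `COC(=O)c1cc(-c2cccc(NC(=O)c3ccc(/C=C/C(=O)c4ccccc4OC)cc3)c2)on1` gives > 40 ug/mL, which is a limit of the assay rather than a number. Compound 2 `COC(=O)c1cc(-c2cccc(NC(=O)c3ccc(/C=C/C(=O)c4ccc(C)c(F)c4)cc3)c2)on1` carries 3-fluoro-4-methylphenyl in place of 2-methoxyphenyl on a carbonyl carbon, and in this assay compound 2 gives > 50 ug/mL, again a limit and not a number. The step that the two limits leave unreadable from compound 1 to compound 2 therefore cannot be read, since both ends sit at limits: the limit of > 40 ug/mL in this assay, at which 1 of the 2 values shown sits, and (the limit of > 50 ug/mL in this assay, at which 1 of the 2 values shown sits). Going by the values given here, compound 2 thus stands at a limit, with no measured number on this read-out, and the same holds for the only other value shown.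

Compound 3 `COC(=O)c1cc(-c2cccc(NC(=O)c3ccc(/C=C/C(=O)c4ccc(Cl)cc4Cl)cc3)c2)on1` differs from compound 2 by 2,4-dichlorophenyl in place of 3-fluoro-4-methylphenyl on a carbonyl carbon. Among the compounds with values here, no measured step bears on this change, as the one step measured on the same carbonyl carbon is unreadable. With both measured compounds showing no toxicity up to their limits, compound 3 is expected to behave alike. The step is estimated as a number no higher from compound 2 to compound 3 (the limit leaves the size open), meaning no change beyond the scatter. Compound 3 is therefore expected to give 50 ug/mL in this assay, with a range from 30 ug/mL to 85 ug/mL, most likely again reported only as a limit.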

Compound 3, half-maximal cytotoxic concentration: > 40 ug/mL
Compound 3: a limit, no number; the forecaster's own chance of this, stated with the estimate: 75%; the middle value lies beyond the limit too.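

In this assay compound 3 gives > 40 ug/mL, which is a limit and not a number. Going by these compounds alone, compound 1 and compound 2 also stand at limits, so no step to compound 3 can be read from either of them. The compounds shown leave open whether changing the group on the carbonyl carbon alters toxicity, and at what concentration any of the three becomes toxic.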